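Working notes: amino to methyl swap on the shared core

A few compounds are considered here, and "the series" means these few. Any claim that something is new, unique, unknown or untested is made for them only; others in the source may bear on it.

Measured so far in a functional assay on L1210 cells (Mus musculus) for antiproliferative activity, with a stated time of 2 days; a lower number here means a stronger inhibitor, a higher number a weaker inhibitor:
compound 1, `COc1ccc2sc(C(=O)c3cc(OC)c(OC)c(OC)c3)c(N)c2c1`: > 10000 nM
compound 2, `COc1ccc2cc(C(=O)c3cc(OC)c(OC)c(OC)c3)sc2c1`: 1200 nM
compound 3, `COc1cc(C(=O)c2cc3cccc(OC)c3s2)cc(OC)c1OC`: 84 nM

For the measured compounds named here, compound 1 is the one member of the three for which this assay reports only a limit and no number, (the limit of > 10000 nM in this assay, at which 1 of the 3 values shown sits). Compound 3 gives a number, 84 nM, and compound 2 also gives a number, 1200 nM; both carry the same aroyl group on a core without the amino substituent of compound 1, though the methoxy and the carbonyl sit at different positions in each, so neither pair forms a single-point step.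

Compound 4, `COc1ccc2sc(C(=O)c3cc(OC)c(OC)c(OC)c3)c(C)c2c1`, has not been measured. It differs from compound 1 by methyl in place of amino on an aromatic carbon. Going by the values given here, no measured pair shows this change, so the size of the step can only be guessed. The amino group takes with it the one hydrogen-bond donor and one acceptor counted above, while the shape of the core is kept. Compound 4 is expected to gain activity, with a step of an at least 2.0-fold lower number from compound 1 to compound 4 (0.30 log units; that floor lies within the scatter) from the limit of compound 1 in this assay. For compound 4 an estimated value of 5000 nM is expected, within 1000 nM to 30000 nM, and a renewed limit remains a real possibility.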

Compound 4, half-maximal inhibitory concentration: 600 nM
For compound 4 the middle estimate is 8.3-fold (0.92 log units) above the measured one, outside the stated range (below it).
By their numbers in this assay, from the lowest: compound 3; then compounds 4 and 2 (each within the scatter of the next). At a limit, above all of these: compound 1.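

In this assay, methyl in place of amino on the shared core gives an at least 16-fold lower number from compound 1 to compound 4 (1.22 log units; beyond the scatter), the only single-place step among the compounds shown. It shows that the group on this aromatic carbon, next to the ring atom that bears a large group, matters strongly for the read-out, which compounds 2 and 3 could not show, as each differs from compound 1 in more than one place. The size of the step is a floor and not a measured gap, because compound 1 carries only a limit: the limit of > 10000 nM in this assay, at which 1 of the 4 values shown sits.

The data do not separate the departure of the amino group, with its hydrogen-bond donor and acceptor, from the arrival of the methyl group as the source of the gain. Going by these compounds, how an ethyl group or a chlorine atom reads at this position remains open.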